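Acetyl in Place of Hydrogen: Cytotoxicity Across Four Analogues

The compounds below may be only part of what the source reports. "The series", "measured", "known", "first", "only" and "open" are said of these compounds alone.

Compound 1, `CCOC(=O)c1cc(CCCOc2ccc(-c3noc(C(F)(F)F)n3)cc2N)on1`, in an ADME assay on HeLa cells (Homo sapiens) for cytotoxicity, read by crystal violet staining, with a stated time of 72 h (on this read-out higher numbers stand for lower toxicity in this test and lower numbers for higher toxicity in this test), gives > 100000 nM, which is a limit of the assay rather than a number.
Compound 2, `CCOC(=O)c1cc(CCCOc2ccc(-c3noc(C(F)(F)F)n3)cc2NC(C)=O)on1`, in this assay gives > 100000 nM, again a limit.
Compound 3, `CN(C)C(=O)c1cc(CCCOc2ccc(-c3noc(C(F)(F)F)n3)cc2N)on1`, in this assay gives 90800 nM.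

Compound 1 and compound 2 differ in one place: acetyl in place of hydrogen on a nitrogen on an aromatic ring. Both values sit at the limit of > 100000 nM in this assay, at which 2 of the 3 values shown sit, so the step that the two limits leave unreadable from compound 1 to compound 2 cannot be read. Compound 1 and compound 3 differ in their cores: dimethylamino in place of ethoxy on a carbonyl carbon. This step is an at least 1.1-fold lower number from compound 1 to compound 3 (0.04 log units; that floor lies within the scatter), a difference that lies within the usual scatter, so the two compounds cannot be ranked against each other.

Compound 4, `CC(=O)Nc1cc(-c2noc(C(F)(F)F)n2)ccc1OCCCc1cc(C(=O)N(C)C)no1`, has not yet been measured. It stands to compound 3 exactly as compound 2 stands to compound 1: acetyl in place of hydrogen on a nitrogen on an aromatic ring. The place of the change is described in the same words in both pairs, so this is the same change, carried onto the other core; the two cores differ in the way already given for compound 1 and compound 3.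

Going by the values given here, the one earlier example of this change gave no readable step, and compound 3 already sits close to the limit of the assay. Compound 4 in this assay is therefore expected near 100000 nM, most likely between 40000 nM and 250000 nM. This estimate means a step of a 1.1-fold higher number from compound 3 to compound 4 (0.04 log units; within the scatter), and it rests on compound 3 with 90800 nM together with the unreadable step that the two limits leave unreadable from compound 1 to compound 2. A result reported only as a limit is likely.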

Compound 4, half-maximal cytotoxic concentration: > 100000 nM
Compound 4: no number, only a limit; the forecaster's own chance of this, stated with the estimate: 60%; the middle value lies on the limit itself.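

In this assay compound 4 gives > 100000 nM, which is a limit of the assay and not a number. Carried onto the core of compound 3, acetyl in place of hydrogen gives an at least 1.1-fold higher number from compound 3 to compound 4 (0.04 log units; that floor lies within the scatter), so this change shows no shift beyond the usual scatter on this core, although its full size stays unknown. The same change on the core of compound 1 and the step from compound 2 to compound 4 cannot be read, since each has a limit at both ends, so the series does not show whether the change acts alike on the two cores, only that neither acetamido compound gives a number: the limit of > 100000 nM in this assay, at which 3 of the 4 values shown sit.

The compounds shown leave open whether any other group on this nitrogen, such as a propionyl group with its longer chain or a methanesulfonyl group, would give a value clearly away from the limit. They also leave open how a carboxylic acid in place of the ethyl ester or the dimethylamide would read in this assay, with the amino or the acetamido group in place.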